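Benzyloxy to 2-Hydroxyphenyl: What Compound 3 Might Show

This account rests on a few compounds, and the source may have more. Where it says the series, first, only, none or still open, it means among the compounds named here.

Compound 1 `COc1ccc(C(OCc2ccccc2)c2cccc3ccccc23)c(OC)c1OC` was examined in a functional assay on MCF7 cells (Homo sapiens) for inhibition, read by sulforhodamine B assay, with a stated time of 48 h (a lower number here means a stronger inhibitor, a higher number a weaker inhibitor), where compound 1 gives 14100 nM. Its companion, compound 2 `COc1ccc(/C(=C\c2ccc(F)cc2)c2cccc3ccccc23)c(OC)c1OC`, gives 17700 nM in this assay; the two numbers lie within the scatter of each other, so neither can be set apart from the other. Compound 3 `COc1ccc(C(c2ccccc2O)c2cccc3ccccc23)c(OC)c1OC` differs from compound 1 by 2-hydroxyphenyl in place of benzyloxy on a saturated chain carbon bound to two aromatic carbons. Among the compounds with values here, no measured pair shows the effect of such a change, so the step of a 1.3-fold lower number from compound 1 to compound 3 (0.11 log units; within the scatter) is expected to be small, in no firm direction. Compound 3 is therefore expected to give about 11000 nM in this assay, within 3000 nM to 40000 nM.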

Compound 3, half-maximal inhibitory concentration: 16600 nM
Compound 3: middle estimate off by 1.5-fold (0.18 log units), on the low side; the range from low to high includes it.
By their numbers in this assay, from the lowest: compounds 1, 3 and 2 (each within the scatter of the next).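

In this assay the exchange of benzyloxy for 2-hydroxyphenyl on a saturated chain carbon bound to two aromatic carbons gives a 1.2-fold higher number from compound 1 to compound 3 (0.07 log units; within the scatter) and so does not set the two compounds apart. Within the data shown here, this is the first measured pair at this position, and the entering group brings a hydrogen-bond donor that the leaving group lacks, without a step beyond the scatter. Going by these compounds, whether an amine or a carboxylic acid on this carbon would give a step beyond the scatter remains open. Nothing measured here accounts for the result.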